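Cyclohexyl for methyl on the carbonyl carbon

This account rests on a few compounds, and the source may have more. Where it says the series, first, only, none or still open, it means among the compounds named here.

compound 1 `O=C(OC1CCC(CN2CCN(c3cc(=O)c4cc(C(F)(F)F)cc([N+](=O)[O-])c4s3)CC2)CC1)c1ccncc1` gives > 64 ug/mL as a limit
compound 2 `Cc1ccc(C(=O)OC2CCC(CN3CCN(c4cc(=O)c5cc(C(F)(F)F)cc([N+](=O)[O-])c5s4)CC3)CC2)cc1` gives > 64 ug/mL as a limit
compound 3 `CC(=O)OC1CCC(CN2CCN(c3cc(=O)c4cc(C(F)(F)F)cc([N+](=O)[O-])c4s3)CC2)CC1` gives > 64 ug/mL as a limit

In an ADME assay on Vero cells (Chlorocebus sabaeus) for cytotoxicity, read by MTT assay, with a stated time of 48 h (a lower number here means a stronger inhibitor, a higher number a weaker inhibitor), compound 3 stands at > 64 ug/mL and this is a limit, not a number. For the measured compounds named here, the picture across the series is the limit of > 64 ug/mL in this assay, at which 3 of the 3 values shown sit, and no measured compound gives a number.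

Compound 4 `O=C(OC1CCC(CN2CCN(c3cc(=O)c4cc(C(F)(F)F)cc([N+](=O)[O-])c4s3)CC2)CC1)C1CCCCC1` differs from compound 3 as follows: cyclohexyl in place of methyl on a carbonyl carbon with cyclohexyl in place of methyl on a carbonyl carbon.

Three measured steps change the group on that same carbonyl carbon. Going by the values given here, the first is a step that the two limits leave unreadable from compound 2 to compound 3 and the others are a step that the two limits leave unreadable from compound 1 to compound 2 and a step that the two limits leave unreadable from compound 1 to compound 3 so none of them offers a size to carry over.

With a step that the two limits leave unreadable from compound 1 to compound 3 as a guide, no clear step is expected in this assay in either direction. The expected step is a step that the limit leaves unreadable from compound 3 to compound 4 and this remains a rough estimate. For compound 4 the estimated value is 90 ug/mL with an expected range of 45 ug/mL to 180 ug/mL and a report as a limit is the likely outcome.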

Compound 4, half-maximal inhibitory concentration: > 64 ug/mL
Compound 4 ended at the assay's limit; the forecaster's own chance of this, stated with the estimate: 85%; the middle value is on the limit's open side.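

In this assay compound 4 gives > 64 ug/mL as a limit and not a number. Its steps with compound 1, compound 2 and compound 3 therefore cannot be read. The compounds shown leave open whether any group on the carbonyl carbon changes this read-out, because all four sit at one limit: the limit of > 64 ug/mL in this assay, at which 4 of the 4 values shown sit.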